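The compounds below may be only part of what the source reports. "The series", "measured", "known", "first", "only" and "open" are said of these compounds alone.

Compound 1 `C/C(=C\c1cc(-c2ccccc2)cs1)C(N)=O` — in a functional assay on HeLa cells (Homo sapiens) for cytotoxicity, read by CCK-8 assay, with a stated time of 24 h (a higher number here means a weaker inhibitor, a lower number a stronger inhibitor), compound 1 gives 12700 nM.
Compound 2 `C/C(=C\c1cc(-c2ccc(C)cc2)cs1)C(N)=O` — in this assay compound 2 reaches only the limit of the assay, > 50000 nM.
Compound 3 `C/C(=C\c1cc(-c2ccc(C#N)cc2)cs1)C(N)=O` — in this assay compound 3 gives 250 nM.

Going by the values given here, compound 3 has the lowest number among the three, and only two of them are numbers at all; compound 2 sits at the limit (the limit of > 50000 nM in this assay, at which 1 of the 3 values shown sits). The nearest number is that of compound 1, and the step is large: a 51-fold lower number from compound 1 to compound 3 (1.71 log units; beyond the scatter). The step from the limit is also large: an at least 200-fold lower number from compound 2 to compound 3 (2.30 log units; beyond the scatter).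

Compound 4 `C/C(=C\c1cc(-c2ccc(S(C)(=O)=O)cc2)cs1)C(N)=O` differs from compound 3 in one place: methylsulfonyl in place of cyano on an aromatic carbon. Among the compounds with values here, the steps that bear on this change are those into compound 3, where cyano on that aromatic carbon brought the number far down from both hydrogen and methyl; none of the measured steps shows methylsulfonyl at that place. Within the data shown here, since the large gain belongs to cyano and cyano now leaves, a rise in this assay is expected, though methylsulfonyl is a new group with no measured precedent here. The step from compound 3 to compound 4 is estimated at a 6.0-fold higher number from compound 3 to compound 4 (0.78 log units; beyond the scatter). For compound 4 the expected value in this assay is 1500 nM, with a range from 300 nM to 8000 nM.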

Compound 4, half-maximal inhibitory concentration: > 50000 nM
Compound 4 was reported as a limit (the forecaster's own chance of this, stated with the estimate: 10%); middle value at least 33-fold (1.52 log units) from the limit.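

At this place, on an aromatic carbon para to a large group, the low number of compound 3 in this assay does not carry over to methylsulfonyl, which gives an at least 200-fold higher number from compound 3 to compound 4 (2.30 log units; beyond the scatter) and shows that the earlier gain does not extend to this other group. Methylsulfonyl also stands on the weak side of the unsubstituted compound, with an at least 3.9-fold higher number from compound 1 to compound 4 (0.59 log units; beyond the scatter) beyond the scatter, so among the four compounds only cyano lowers the number relative to hydrogen, while methyl and methylsulfonyl both go against any general gain from a group at this place. Compound 4 is reported as a limit, as is compound 2, and the step between those two cannot be read: the limit of > 50000 nM in this assay, at which 2 of the 4 values shown sit.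

On these data alone, what remains open is whether cyano is unique at this place, or whether a group such as a primary amine, a carboxylic acid or a nitro group would also bring the number down in this assay. The compounds shown also leave open whether the gain from cyano would hold at another place on the same ring.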